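A few compounds are considered here, and "the series" means these few. Any claim that something is new, unique, unknown or untested is made for them only; others in the source may bear on it.

Measured in a functional assay on Raji cells (Homo sapiens) for cytotoxicity, with a stated time of 72 h (on this read-out lower numbers stand for an effect already at smaller amounts and higher numbers for an effect only at larger amounts of compound), each value a limit and not a number:
- Compound 1 `C=C[C@@](C)(/C=C/c1ccc(O)c(CO)c1)CCC=C(C)C`: > 26000 nM
- Compound 2 `C=C[C@@](C)(/C=C/c1ccc(O)c(/C=C/C#N)c1)CCC=C(C)C`: > 26000 nM
- Compound 3 `C=C[C@@](C)(/C=C/c1ccc(O)c(/C=C/C(=O)OCc2ccccc2)c1)CCC=C(C)C`: > 26000 nM

Compound 2 stands only at a limit, > 26000 nM. That is the limit of > 26000 nM in this assay, at which 3 of the 3 values shown sit, so compound 1 and compound 3 offer no number either. Compound 4 `C=C[C@@](C)(/C=C/c1ccc(O)c(/C=C(\C)C(=O)OCC)c1)CCC=C(C)C` carries 2-(ethoxycarbonyl)prop-1-en-1-yl in place of 2-cyanoethenyl on an aromatic carbon, ortho to a hydroxy group: 2-(ethoxycarbonyl)prop-1-en-1-yl in place of 2-cyanoethenyl on an aromatic carbon. Going by the values given here, two measured steps bear on this change, a step that the two limits leave unreadable from compound 1 to compound 2 and a step that the two limits leave unreadable from compound 2 to compound 3, and neither has a readable size. The expected change is therefore a step that the limit leaves unreadable from compound 2 to compound 4, with no direction and no size beyond the scatter in this assay. Another limit is the likeliest report. For compound 4 the estimate is 30000 nM, expected within 15000 nM to 60000 nM.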

Compound 4, half-maximal effective concentration: > 26000 nM
Compound 4: a limit, no number (the forecaster's own chance of this, stated with the estimate: 85%); the middle value lies beyond the limit too.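

Compound 4 gives only a limit, as do compound 1 and compound 2, so neither new step can be read. The compounds shown leave open how the groups on the shared core compare in this assay.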